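Lactam series: oxolan-2-yl in place of methyl at the benzylic side chain

The compounds below may be only part of what the source reports. "The series", "measured", "known", "first", "only" and "open" are said of these compounds alone.

Measured compounds:
- compound 1, `COC(c1cc(Cl)c2c(c1Cl)C(=O)N(Cc1c(C)cc(C)[nH]c1=O)CC2)C1CCN(C(C)=O)CC1`: 1620 nM; 22 nM (2 entries)
- compound 2, `Cc1cc(C)c(CN2CCc3c(Cl)cc([C@@H](C)CO)c(Cl)c3C2=O)c(=O)[nH]1`: 1500 nM

Among the measured compounds shown here, compound 2 is the only member with a single value to hand; a further entry for compound 2 carries no single number. In a functional assay on KARPAS-422 cells (Homo sapiens) for antiproliferative activity, read by resazurin assay, with a stated time of 72 h (a lower number here means a stronger inhibitor, a higher number a weaker inhibitor), compound 2 gives 1500 nM. Compound 1 is recorded twice, and the two entries in the several entries of compound 1 in this assay, 1620 nM; 22 nM (2 entries) lie far apart, so the only firm anchor for the side chain is compound 2. Compound 1 and compound 2 differ in more than one place, so their values are only set side by side.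

The untested member is compound 3, `Cc1cc(C)c(CN2CCc3c(Cl)cc([C@H](CO)[C@@H]4CCCO4)c(Cl)c3C2=O)c(=O)[nH]1`. The change from compound 2 is oxolan-2-yl in place of methyl on a saturated chain carbon bound to an aromatic carbon and a saturated chain carbon.

For the measured compounds named here, no step between measured compounds covers this change, so its size is open. The wide spread in the several entries of compound 1 in this assay, 1620 nM; 22 nM (2 entries) shows that a larger substituent on that chain carbon can reach a much stronger value than compound 2, which makes a gain rather than a loss the more likely direction, of moderate size. The expected step is a 3.8-fold lower number from compound 2 to compound 3 (0.57 log units; beyond the scatter). In this assay compound 3 is expected at 400 nM, with a range from 60 nM to 2500 nM.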

Compound 3, half-maximal inhibitory concentration: 57 nM
For compound 3 the middle estimate is 7.0-fold (0.85 log units) above the measured one; the whole stated range lies above it.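

In this assay, oxolan-2-yl in place of methyl on a saturated chain carbon bound to an aromatic carbon and a saturated chain carbon gives a 26-fold lower number from compound 2 to compound 3 (1.42 log units; beyond the scatter), the only step at this position that can be read among the compounds shown. This chain carbon therefore accepts a five-membered non-aromatic ring carrying one hetero atom, and the change brings a large gain rather than a loss. Compound 1 adds no firm second reference, as it differs from compound 3 in more than one place and its entries lie far apart: the several entries of compound 1 in this assay, 1620 nM; 22 nM (2 entries)

The compounds shown do not separate the contribution of the ring from that of its oxygen, so cyclopentyl or an open chain such as 2-methoxyethyl on the same carbon would be needed to tell the two apart. Also open is how much depends on the defined stereocentre that enters with the oxolan-2-yl group, as the opposite configuration at that ring carbon does not appear among these compounds.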